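This account rests on a few compounds, and the source may have more. Where it says the series, first, only, none or still open, it means among the compounds named here.

Measured so far:
compound 1 `CCCN(CCC)c1ccc(NC(=O)c2cc(Cl)ccc2O)c(Cl)c1` gives 323000 nM
compound 2 `O=C(Nc1ccc(NC2CCCC2)cc1Cl)c1cc(Cl)ccc1O` gives "not determined" (no result reported)

Within the data shown here, in an ADME assay on A549 cells (Homo sapiens) for cytotoxicity, read by LDH release, with a stated time of 15 h (a lower number here means that less compound is tolerated, a higher number that more compound is tolerated), compound 1 gives 323000 nM as the only number. Compound 2 stands nowhere on that scale: for compound 2 the record reads "not determined" (no result reported) and no comparison with it can be made.

The compound still awaiting measurement is compound 3 `CCCNc1ccc(NC(=O)c2cc(Cl)ccc2O)c(Cl)c1` and it differs from compound 2 in one place. The difference reads propyl in place of cyclopentyl on a nitrogen on an aromatic ring and amounts to propyl in place of cyclopentyl on a nitrogen on an aromatic ring.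

Among the measured compounds shown here, no measured step offers a guide to this exchange, and the missing number for compound 2 leaves nothing to start from. No step beyond the usual scatter, in either direction, is therefore expected. For the measured compounds named here, the expectation leans on the one number available, compound 1 at 323000 nM in this assay as the sole anchor, and the range is kept wide. For compound 3 the concentration is estimated at 300000 nM with an expected range of 100000 nM to 700000 nM when measured.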

Compound 3, half-maximal cytotoxic concentration: 69700 nM
Beside the measured number, compound 3's estimate is 4.3-fold (0.63 log units) above it, outside the stated range (below it).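

In this assay, the nitrogen on the aromatic ring turns out to be a place where the substitution shows up in the read-out: hydrogen in place of one of the two propyl groups gives a 4.6-fold lower number from compound 1 to compound 3 (0.67 log units; beyond the scatter), so the cells tolerate less of the compound that keeps a single propyl group. Among these compounds, this is the first readable step, and it is a single pair at a single place, with the rest of the structure unchanged. The other step, between cyclopentyl and propyl, cannot be read, as compound 2 has no reported result, and no measurement at hand gives a reason for the drop.

The compounds shown leave open whether the trend continues once the last propyl group also gives way to hydrogen, leaving a free primary amine on the aromatic ring, and whether a longer chain such as butyl would move the number in the other direction. They also leave open how an acetyl group on that nitrogen, or a carboxylic acid at the end of the chain, would read in this assay.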